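Extending the sulfur-bound chain from propyl to butyl

The source may report more compounds than this note shows. Statements on the series, on what has been measured and on what is new or still open speak of the compounds shown alone.

In a functional assay on L1210 cells (Mus musculus) for inhibition (a lower number here means a stronger inhibitor, a higher number a weaker inhibitor), compound 1 (`C[S+](=N)([O-])CCC(NC(=O)c1ccc(NCc2cnc3nc(N)nc(O)c3n2)cc1)C(=O)O`) gives 190000 nM, compound 2 (`CC[S+](=N)([O-])CCC(NC(=O)c1ccc(NCc2cnc3nc(N)nc(O)c3n2)cc1)C(=O)O`) gives 220000 nM and compound 3 (`CCC[S+](=N)([O-])CCC(NC(=O)c1ccc(NCc2cnc3nc(N)nc(O)c3n2)cc1)C(=O)O`) gives 300000 nM. Compound 3 stands within the scatter of both other compounds, the wider gap being a 1.6-fold higher number from compound 1 to compound 3 (0.20 log units; within the scatter).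

Compound 4 (`CCCC[S+](=N)([O-])CCC(NC(=O)c1ccc(NCc2cnc3nc(N)nc(O)c3n2)cc1)C(=O)O`) carries one change relative to compound 3: methyl in place of hydrogen on a saturated chain carbon, three bonds along the chain from a sulfur. This is methyl in place of hydrogen on a saturated chain carbon, three bonds along the chain from a sulfur, so propyl becomes butyl.

Two measured steps are the same kind of extension, made closer to the sulfur: a 1.2-fold higher number from compound 1 to compound 2 (0.06 log units; within the scatter) and a 1.4-fold higher number from compound 2 to compound 3 (0.13 log units; within the scatter). Both are small, and neither establishes a trend. Three compounds give no measure of how a longer chain behaves, so the expectation is an extrapolation.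

The expected step is a 1.2-fold higher number from compound 3 to compound 4 (0.08 log units; within the scatter), and no change beyond the scatter is expected. For compound 4 the estimate is 360000 nM, with an expected range of 200000 nM to 650000 nM.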

Compound 4, half-maximal inhibitory concentration: 270000 nM
Beside the measured number, compound 4's estimate is 1.3-fold (0.12 log units) above it, and the stated range covers the measured number.
By their numbers in this assay, from the lowest: compounds 1, 2, 4 and 3 (each within the scatter of the next).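

In this assay, within the data shown here, methyl in place of hydrogen three bonds along the chain from a sulfur gives a 1.1-fold lower number from compound 3 to compound 4 (0.05 log units; within the scatter), and the longer replacements give a 1.2-fold higher number from compound 2 to compound 4 (0.09 log units; within the scatter) and a 1.4-fold higher number from compound 1 to compound 4 (0.15 log units; within the scatter), so no printed step among methyl, ethyl, propyl and butyl leaves the scatter. Methyl in place of hydrogen therefore reads alike at the first and third chain carbons: the same change on two cores in this assay, a 1.2-fold higher number (0.06 log units; within the scatter) from compound 1 to compound 2 and a 1.1-fold lower number (0.05 log units; within the scatter) from compound 3 to compound 4, 1.3-fold (0.11 log units) apart, within the scatter of two such steps The larger replacements, ethyl and propyl, likewise show no separation between the places compared: the same change on two cores in this assay, a 1.6-fold higher number (0.20 log units; within the scatter) from compound 1 to compound 3 and a 1.2-fold higher number (0.09 log units; within the scatter) from compound 2 to compound 4, 1.3-fold (0.11 log units) apart, within the scatter of two such steps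

As far as these compounds go, whether a chain longer than butyl stays within the scatter remains open. Also open, from the compounds shown here alone, is whether a different group at the chain end, such as an amine, a carboxylic acid or a phenyl ring, would move the number beyond it.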